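Taking furan-2-yl off compound 3

A few compounds are considered here, and "the series" means these few. Any claim that something is new, unique, unknown or untested is made for them only; others in the source may bear on it.

In an ADME assay on MDCK cells (Canis lupus familiaris) for cytotoxicity (a lower number here means that less compound is tolerated, a higher number that more compound is tolerated), compound 3 (`O=[N+]([O-])C1=CNc2nc(-c3ccco3)nn2C1c1ccc(O)c(O)c1O`) gives 317000 nM and sits level, within the usual scatter, with compound 1 (`O=[N+]([O-])C1=CNc2ncnn2C1c1ccc(O)c(O)c1`) at 368000 nM on this read-out. Compound 2 (`O=[N+]([O-])C1=CNc2nc(-c3ccco3)nn2C1c1ccc(O)c(O)c1`) gives > 1200000 nM here, which is a limit of the assay and not a number.

The next structure is compound 4 (`O=[N+]([O-])C1=CNc2ncnn2C1c1ccc(O)c(O)c1O`), and the change is hydrogen in place of furan-2-yl on an aromatic carbon in short, hydrogen in place of furan-2-yl on an aromatic carbon.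

Among the compounds with values here, two measured steps bear on this. The same swap, in the opposite direction, gave an at least 3.2-fold higher number from compound 1 to compound 2 (0.51 log units; beyond the scatter) so taking furan-2-yl off compound 3 should bring a lower number of similar or greater size. Within the data shown here, the other step, hydroxy in place of hydrogen on an aromatic carbon, gave an at least 3.7-fold lower number from compound 2 to compound 3 (0.57 log units; beyond the scatter) and was seen only with furan-2-yl in place. Both steps rest on the limit of compound 2, so each gives only a minimum size.

The expected change is a 3.5-fold lower number from compound 3 to compound 4 (0.55 log units; beyond the scatter) in this assay as a modest move beyond the scatter. Compound 4 is estimated at 90000 nM with an expected range from 30000 nM to 270000 nM on this reasoning.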

Compound 4, half-maximal cytotoxic concentration: 405000 nM
Compound 4: middle estimate off by 4.5-fold (0.65 log units), on the low side, outside the stated range (above it).
By their numbers in this assay, from the lowest: compounds 3, 1 and 4 (each within the scatter of the next). At a limit, above all of these: compound 2.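

In this assay, hydrogen in place of furan-2-yl on the aromatic carbon between two ring nitrogen atoms gives a 1.3-fold higher number from compound 3 to compound 4 (0.11 log units; within the scatter), so with the added hydroxy present, this swap leaves the read-out unchanged within the scatter. The same swap made a difference beyond the scatter only on the core without that hydroxy, so the effect of furan-2-yl at this position depends on what the rest of the molecule carries: the same change on two cores in this assay, an at least 3.2-fold higher number (0.51 log units; beyond the scatter) from compound 1 to compound 2 and a 1.3-fold lower number (0.11 log units; within the scatter) from compound 4 to compound 3, at least 4.1-fold (0.61 log units) apart, beyond the scatter of two such steps. The hydroxy change shows the same dependence, giving a 1.1-fold higher number from compound 1 to compound 4 (0.04 log units; within the scatter) when no furan-2-yl is present, although it moved the number beyond the scatter when furan-2-yl was there: the same change on two cores in this assay, an at least 3.7-fold lower number (0.57 log units; beyond the scatter) from compound 2 to compound 3 and a 1.1-fold higher number (0.04 log units; within the scatter) from compound 1 to compound 4, at least 4.1-fold (0.61 log units) apart, beyond the scatter of two such steps.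

On these data alone, both contrasts rest on compound 2, whose value is a limit and not a number, so the true size of each gap stays open: the limit of > 1200000 nM in this assay, at which 1 of the 4 values shown sits. As far as these compounds go, it also remains open whether this dependence belongs to furan-2-yl alone or would also appear with another group on the same carbon, such as a methyl group, an amine or a carboxylic acid.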